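Carbamate in place of piperidine: solubility notes

This account rests on a few compounds, and the source may have more. Where it says the series, first, only, none or still open, it means among the compounds named here.

Compound 1 `COC(=O)CC1CCN(C[C@H]2CN(c3ccc(-n4cc(-c5ccccn5)cn4)c(F)c3)C(=O)O2)CC1` is the reference point of the set. In a physicochemical assay for solubility, read by HPLC, with a stated time of 24 h (on this read-out lower numbers stand for lower solubility and higher numbers for higher solubility), compound 1 gives 92100 nM, the highest of the two numbers to hand. Its nearest neighbour is compound 2 `O=C1O[C@@H](CN2CCC(O)CC2)CN1c1ccc(-n2cc(-c3ccccn3)cn2)c(F)c1`, where a 2.0-fold lower number from compound 1 to compound 2 (0.30 log units; within the scatter). In this assay compound 2 gives 45900 nM. Compound 3 `O=C(OC[C@H]1CN(c2ccc(-n3cc(-c4ccccn4)cn3)c(F)c2)C(=O)O1)c1ccccc1` is known only as a limit of this assay: compound 3 gives <= 65400 nM. the limit of <= 65400 nM in this assay, at which 1 of the 3 values shown sits, covers that value, so the step that the limit leaves unreadable from compound 2 to compound 3 stays unread.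

Compound 4 `COC(=O)NC[C@H]1CN(c2ccc(-n3cc(-c4ccccn4)cn3)c(F)c2)C(=O)O1` is not yet measured. Its change from compound 1 is (methoxycarbonyl)amino in place of 4-((methoxycarbonyl)methyl)piperidin-1-yl on a saturated chain carbon bound to a saturated ring carbon. Within the data shown here, two measured steps bear on it: an at least 1.4-fold lower number from compound 1 to compound 3 (0.14 log units; that floor lies within the scatter) also removes the 4-((methoxycarbonyl)methyl)piperidin-1-yl group from the same place, while a 2.0-fold lower number from compound 1 to compound 2 (0.30 log units; within the scatter) keeps that ring. The step to compound 3 is the closer pattern, yet its floor sits within the scatter, so only a modest downward move, if any, is expected. For compound 4 the expected step is a 3.1-fold lower number from compound 1 to compound 4 (0.49 log units; beyond the scatter). The estimate for compound 4 in this assay is 30000 nM, within 8000 nM to 90000 nM.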

Compound 4, solubility: 34100 nM
Beside the measured number, compound 4's estimate is 1.1-fold (0.06 log units) below it, and the stated range covers the measured number.
By their numbers in this assay, from the lowest: compounds 4, 2 and 1 (each within the scatter of the next, the first and the last beyond it).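

Among these compounds, at the saturated chain carbon bound to a saturated ring carbon, (methoxycarbonyl)amino in place of 4-((methoxycarbonyl)methyl)piperidin-1-yl gives a 2.7-fold lower number from compound 1 to compound 4 (0.43 log units; beyond the scatter), the first step that reads beyond the scatter in this assay. Compound 2, which keeps the piperidine ring, is not separated from compound 4, the step being a 1.3-fold lower number from compound 2 to compound 4 (0.13 log units; within the scatter), so losing the ring does not by itself set compound 4 apart from compound 2. Compound 3 remains a limit, and the steps to it from compound 2 and compound 4 cannot be read: the limit of <= 65400 nM in this assay, at which 1 of the 4 values shown sits.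

Open, on these data alone, is whether the step from compound 1 follows the loss of the ring or the loss of its (methoxycarbonyl)methyl group. Also open, as far as these compounds go, is how a simple amine or a carboxylic acid would read at the same place.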